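Acetyl for methyl on the aromatic nitrogen

The source may report more compounds than this note shows. Statements on the series, on what has been measured and on what is new or still open speak of the compounds shown alone.

Measured so far in a functional assay on RPMI-8226 cells (Homo sapiens) for cytotoxicity, read by fluorescence, with a stated time of 72 h (a lower number here means a stronger inhibitor, a higher number a weaker inhibitor), as follows
compound 1 `CCOC(=O)n1nc(N)c(/N=N/c2ccc(O)cc2)c1N` gives > 100000 nM (a limit)
compound 2 `Cn1nc(N)c(/N=N/c2ccc(O)cc2)c1N` gives > 100000 nM (a limit)

Compound 2 stands only at a limit and has no numerical value. Compound 3 `CC(=O)n1nc(N)c(/N=N/c2ccc(O)cc2)c1N` keeps the core of compound 2 and differs by acetyl in place of methyl on an aromatic nitrogen in one place, with acetyl in place of methyl on an aromatic nitrogen. Going by the values given here, the only measured step on this nitrogen is a step that the two limits leave unreadable from compound 1 to compound 2 and it gives no usable size. The series offers the limit of > 100000 nM in this assay, at which 2 of the 2 values shown sit, as its whole evidence. Among the compounds with values here, because of the limit of > 100000 nM in this assay, at which 2 of the 2 values shown sit, no step of real size is expected in this assay and no direction can be assigned. The expected step is a number no higher from compound 2 to compound 3 (the limit leaves the size open) and this amounts to none beyond the scatter. Compound 3 is estimated at 100000 nM (range 40000 nM to 200000 nM) and is expected to be reported most probably as a limit.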

Compound 3, half-maximal inhibitory concentration: > 100000 nM
Compound 3: only a limit was reported; the forecaster's own chance of this, stated with the estimate: 85%; the middle value sits exactly at the limit.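

No step among compound 1, compound 2 and compound 3 can be read, since all three stand at a single limit and none has a numerical value: the limit of > 100000 nM in this assay, at which 3 of the 3 values shown sit.

The compounds shown leave open whether any group on this aromatic nitrogen would give a numerical value in this assay, and how large a step between such groups would be.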